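The compounds below may be only part of what the source reports. "The series", "measured", "known", "first", "only" and "open" are said of these compounds alone.

In a functional assay on HL-60 cells (Homo sapiens) for inhibition, read by CCK-8 assay, with a stated time of 48 h (a lower number here means a stronger inhibitor, a higher number a weaker inhibitor), compound 1 (`O=C(NCCNS(=O)(=O)c1ccc(-c2ccccc2Oc2ccc(O)c(O)c2)s1)Nc1cc(Cl)cc(Cl)c1`) gives 10400 nM and compound 2 (`O=C(NCCNS(=O)(=O)c1ccc(-c2ccccc2Oc2ccc([N+](=O)[O-])c([N+](=O)[O-])c2)s1)Nc1cc(Cl)cc(Cl)c1`) gives 2300 nM while compound 3 (`COc1cccc(NC(=O)NCCNS(=O)(=O)c2ccc(-c3ccccc3OCc3ccccc3)s2)c1`) gives 1700 nM as its half-maximal inhibitory concentration. Compound 3 and compound 2 lie within the scatter of each other, and the value of compound 1 is higher than both. Compound 4 (`O=C(NCCNS(=O)(=O)c1ccc(-c2ccccc2OCc2ccccc2)s1)Nc1cc(Cl)cc(Cl)c1`) departs from compound 3 in one place (3,5-dichlorophenyl in place of 3-methoxyphenyl on an amide-type nitrogen) with 3,5-dichlorophenyl in place of 3-methoxyphenyl on an amide-type nitrogen. Among the compounds with values here, the one measured step, a 4.5-fold lower number from compound 1 to compound 2 (0.66 log units; beyond the scatter) on exchanging 3,4-dihydroxyphenyl for 3,4-dinitrophenyl, bears only indirectly on this change. That step concerns a different group, and both of its compounds already carry 3,5-dichlorophenyl. Within the data shown here, no measured pair isolates the exchange of 3-methoxyphenyl for 3,5-dichlorophenyl, so the size of that exchange remains unknown, and the wide gap between the two compounds carrying 3,5-dichlorophenyl argues for caution. No shift beyond the scatter is therefore expected in this assay, and the expected step is a 1.1-fold lower number from compound 3 to compound 4 (0.05 log units; within the scatter) for this exchange. Compound 4 is estimated at 1500 nM with an expected range of 500 nM to 4500 nM in this measurement.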

Compound 4, half-maximal inhibitory concentration: 11700 nM
Estimate against measurement, compound 4: 7.8-fold (0.89 log units) below; the measured number lies above the stated range.
By their numbers in this assay, from the lowest: compounds 3 and 2 (each within the scatter of the next); then compounds 1 and 4 (each within the scatter of the next).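

In this assay, within the data shown here, the urea's aryl group matters: with benzyl held on the oxygen, 3,5-dichlorophenyl in place of 3-methoxyphenyl on the amide-type nitrogen gives a 6.9-fold higher number from compound 3 to compound 4 (0.84 log units; beyond the scatter), the first reading of this exchange on its own. With 3,5-dichlorophenyl held on that nitrogen, the group on the oxygen can also be compared against benzyl: the change from 3,4-dinitrophenyl gives a 5.1-fold higher number from compound 2 to compound 4 (0.71 log units; beyond the scatter), whereas the change from 3,4-dihydroxyphenyl gives a 1.1-fold higher number from compound 1 to compound 4 (0.05 log units; within the scatter), so among these three compounds only the one with 3,4-dinitrophenyl stands apart. Nothing among the data shown accounts for the size or direction of these steps.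

As far as these compounds go, the exchange on the nitrogen rests on a single pair, so it remains open whether the same step would appear with 3,4-dinitrophenyl or 3,4-dihydroxyphenyl on the oxygen in place of benzyl. From the compounds shown here alone, it is also open whether a 3-chlorophenyl or a 3,5-dimethoxyphenyl on that nitrogen would give a value close to that of compound 3 or to that of compound 4.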